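Cyclopropyl in Place of Hydrogen: Toxicity Outlook for Compound 4

The source may report more compounds than this note shows. Statements on the series, on what has been measured and on what is new or still open speak of the compounds shown alone.

The series shares the core of compound 1 `COc1cccc(NC(=O)c2nnn(Cc3ccc(-n4cccn4)cc3)c2N)c1`. In a toxicity assay on Vero cells (Chlorocebus sabaeus) for inhibition (a lower number here means that less compound is needed, a higher number that more compound is needed for the effect), compound 1 gives > 50100 nM, which is a limit of the assay and not a number. Compound 2 `COc1cccc(NC(=O)c2nnn(Cc3ccccc3)c2N)c1` carries the unsubstituted benzyl arm; in this assay compound 2 gives > 50100 nM, again a limit. Compound 3 `COc1cccc(NC(=O)c2nnn(CC3CCN(C(=O)OC(C)(C)C)CC3)c2N)c1` completes the measured set, and in this assay compound 3 gives > 50100 nM, also a limit. Every measured value therefore sits at the limit of > 50100 nM in this assay, at which 3 of the 3 values shown sit, and compound 2 stands exactly where the other two stand. Because both ends of a step that the two limits leave unreadable from compound 1 to compound 2 are limits, the size of that step cannot be read.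

Compound 4 `COc1cccc(NC(=O)c2nnn(Cc3ccc(C4CC4)cc3)c2N)c1` is still to be measured. It differs from compound 2 by cyclopropyl in place of hydrogen on an aromatic carbon. Within the data shown here, no measured step bears on this change in a readable way; the only comparison available is the unreadable one above. With three out of three values at the same limit, compound 4 is expected to show a step that the limit leaves unreadable from compound 2 to compound 4, that is, no step beyond the scatter. Compound 4 is estimated at 60000 nM in this assay, with a range from 30000 nM to 120000 nM, most likely reported as a limit again.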

Compound 4, half-maximal effective concentration: > 50100 nM
Compound 4: a limit, no number; the forecaster's own chance of this, stated with the estimate: 85%; the middle value is on the limit's open side.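

In this assay, among these compounds, compound 4 gives > 50100 nM as a limit and not a number, so no step from compound 1 or compound 2 to compound 4 can be read. The whole set stays at one value: the limit of > 50100 nM in this assay, at which 4 of the 4 values shown sit. The compounds shown leave open whether any change on the arm of the shared core gives a readable number in this assay at all.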